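This account rests on a few compounds, and the source may have more. Where it says the series, first, only, none or still open, it means among the compounds named here.

Compound 1 `CCCC(C)Oc1ccc(C(=O)/C=C/c2c(/C=C/c3ccc(OC)cc3)cc(OC)cc2OC)cc1` – 6.7 ug/mL
Compound 2 `COc1ccc(/C=C/c2cc(OC)cc(OC)c2/C=C/C(=O)c2ccc(C(F)(F)F)cc2)cc1` – 4.3 ug/mL

Both values were measured in a functional assay on B16-F10 cells (Mus musculus) for antiproliferative activity, read by MTT assay, with a stated time of 48 h; a lower number here means a stronger inhibitor, a higher number a weaker inhibitor. In this assay compound 2 sits within the scatter of compound 1, so the two cannot be ranked. Compound 3 (`COc1ccc(/C=C/c2cc(OC)cc(OC)c2/C=C/C(=O)c2ccc(N)cc2)cc1`) keeps the core of compound 2 but has amino in place of trifluoromethyl on an aromatic carbon, para to a large group (amino in place of trifluoromethyl on an aromatic carbon). Going by the values given here, the single measured step that bears on this change also replaces one group on an aromatic carbon with another. That step, a 1.6-fold lower number from compound 1 to compound 2 (0.19 log units; within the scatter), stayed small. Among the compounds with values here, no measured compound carries amino, so this evidence is thin and the range must stay wide. On that basis, no shift beyond the scatter is expected in this assay, and no direction can be favoured with confidence. The estimated step is small (a 1.2-fold higher number from compound 2 to compound 3 (0.07 log units; within the scatter)). The expected value for compound 3 is 5 ug/mL (estimated range 2 ug/mL to 12 ug/mL).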

Compound 3, half-maximal inhibitory concentration: 2.8 ug/mL
Estimate against measurement, compound 3: 1.8-fold (0.25 log units) above; the measured number falls inside the stated range.
By their numbers in this assay, from the lowest: compounds 3, 2 and 1 (each within the scatter of the next, the first and the last beyond it).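

In this assay the position on an aromatic carbon para to a large group accepts amino, with one hydrogen-bond donor, in place of trifluoromethyl, with none: the swap gives a 1.5-fold lower number from compound 2 to compound 3 (0.19 log units; within the scatter) and does not separate the two compounds. Against 1-methylbutoxy the picture differs, since amino gives a 2.4-fold lower number from compound 1 to compound 3 (0.38 log units; beyond the scatter) and this is the only step at this position that passes beyond the scatter, though only modestly, while compound 2 stays within the scatter of both neighbours. The compounds therefore span a narrow band at this position, and nothing shown explains the one step that can be read as real.

Going by these compounds alone, with only three groups at this place, the data cannot say whether the step away from 1-methylbutoxy follows the size of the group, the presence of a hydrogen-bond donor, or neither, because amino differs from it in both counts. Going by these compounds, it remains open whether a hydroxyl, a dimethylamino group, a carboxylic acid or a shorter alkoxy chain such as methoxy would fall with compound 3 or with compound 1.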